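A Methoxy Group Replaces Chloro on the Benzyl Ring

The compounds below may be only part of what the source reports. "The series", "measured", "known", "first", "only" and "open" are said of these compounds alone.

Compound 1, `CCc1ccccc1N(Cc1nnc(Cc2ccccc2)o1)S(=O)(=O)c1ccc(C)cc1`: 398 nM in a functional assay on CHO cells for antagonist activity at prostaglandin E2 receptor EP1 subtype (Homo sapiens), read by FLIPR and calcium flux; a higher number here means a weaker inhibitor, a lower number a stronger inhibitor
Compound 2, `CCc1ccccc1N(Cc1nnc(Cc2ccc(Cl)cc2)o1)S(=O)(=O)c1ccc(C)cc1`: 316 nM

Within the data shown here, compound 2 carries the lowest of the two numbers so far in this assay, but its only neighbour, compound 1, lies within the scatter of it, so no order between the two can be claimed. Compound 3, `CCc1ccccc1N(Cc1nnc(Cc2ccc(OC)cc2)o1)S(=O)(=O)c1ccc(C)cc1`, differs from compound 2 in a single place: methoxy in place of chloro on an aromatic carbon. Among the measured compounds shown here, only one measured step touches this position on the benzyl ring, a 1.3-fold lower number from compound 1 to compound 2 (0.10 log units; within the scatter), and that step stayed within the scatter. For the measured compounds named here, it shows that a change at this carbon did not move the number clearly, but it says nothing direct about a methoxy group, for which no measured pair exists. The expectation therefore rests on compound 2 alone. For compound 3 the expected step is a 1.1-fold higher number from compound 2 to compound 3 (0.04 log units; within the scatter), with no shift beyond the scatter in either direction. The estimate for compound 3 in this assay is 350 nM, within a range from 150 nM to 800 nM.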

Compound 3, inhibition constant: 631 nM
For compound 3 the middle estimate is 1.8-fold (0.26 log units) below the measured one; the range from low to high includes it.
By their numbers in this assay, from the lowest: compounds 2, 1 and 3 (each within the scatter of the next).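

In this assay, among these compounds, this carbon has now carried hydrogen, chloro and methoxy, and no pair among the three compounds separates clearly. Methoxy in place of chloro gives a 2.0-fold higher number from compound 2 to compound 3 (0.30 log units; within the scatter) while methoxy in place of hydrogen gives a 1.6-fold higher number from compound 1 to compound 3 (0.20 log units; within the scatter) and so a methoxy group, with the hydrogen-bond acceptor it brings, can stand on this carbon without a step beyond the scatter. The step from chloro to methoxy is the largest yet seen at this position, but it still lies within the scatter and cannot be read as a true loss of strength, and nothing available here offers an explanation for the size of any of these steps.

From the compounds shown here alone, what remains open is whether any group on this carbon can move the number beyond the scatter, in either direction, for all three groups seen so far remain within the scatter of one another. An amine, a carboxylic acid or a longer chain such as ethoxy in this same place, on the shared core, would put that question to a sharper test than the three groups compared here.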